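The source may hold more compounds than are shown below. What is called first, only, known or untested is meant among the compounds shown, and "the series" means these compounds.

Measured compounds:
- compound 1 `CC(C)(C)c1cc(N)c2cc(NC(=O)/C=C/c3ccc(C(F)(F)F)cc3)ccc2n1`: 0.3 nM
- compound 2 `CCCc1cc(N)c2cc(NC(=O)C3CCC(c4ccc(Cl)cc4)CC3)ccc2n1`: 4.4 nM
- compound 3 `CCCc1cc(N)c2cc(NC(=O)/C=C/c3ccc(SC)cc3)ccc2n1`: 9 nM

These three values come from an assay on isolated protein for displacement of a labelled ligand from melanin-concentrating hormone receptor 1 (Homo sapiens); a lower number here means a stronger inhibitor, a higher number a weaker inhibitor. Compound 1 stands at the lowest number of the three. The nearest of the others is compound 2, whose number is higher by a margin beyond the scatter, and compound 3 lies further away still, also beyond the scatter. Compound 2 and compound 3 each carry a propyl chain on the shared core, whereas compound 1 carries tert-butyl, but both also differ from compound 1 in the amide portion, so their gap to compound 1 cannot be assigned to any single change.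

Compound 4 `CC(C)c1cc(N)c2cc(NC(=O)/C=C/c3ccc(C(F)(F)F)cc3)ccc2n1` has not yet been measured in this assay. It differs from compound 1 in one place: hydrogen in place of methyl on a saturated chain carbon bound to an aromatic carbon and two saturated chain carbons. For the measured compounds named here, no step between measured compounds isolates this change. With compound 1 at 0.3 nM and the two propyl compounds sitting at higher numbers, a small loss is expected for the shortening to isopropyl, though one that may not exceed the scatter. The step from compound 1 to compound 4 is therefore estimated at a 2.7-fold higher number from compound 1 to compound 4 (0.43 log units; beyond the scatter). Compound 4 is expected to give 0.8 nM, with a likely range from 0.3 nM to 3 nM.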

Compound 4, half-maximal inhibitory concentration: 2.1 nM
Compound 4: the middle estimate sits 2.6-fold (0.42 log units) below what was measured, within the range that was stated.
By their numbers in this assay, from the lowest: compound 1; then compound 4; then compound 2; then compound 3.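

In this assay, for the compounds shown here, the change from tert-butyl to isopropyl on the shared core, with the amide portion left as it is, gives a 7.0-fold higher number from compound 1 to compound 4 (0.85 log units; beyond the scatter) and is the first step here that isolates this position. The earlier compounds shown here could not show this, as compound 2 and compound 3 differ from compound 1 in the amide portion as well as in the chain. The step shows that removing a single methyl from the saturated chain carbon bound to an aromatic carbon and two saturated chain carbons, with no ring, hydrogen-bond donor, hydrogen-bond acceptor or net charge entering or leaving, is enough to move the number beyond the scatter, although no measurement at hand bears on why it does so.

What the compounds shown leave open is how an ethyl, a cyclopropyl or a cyclobutyl group at this place would compare with tert-butyl and isopropyl on the same amide portion. It also remains open whether a step of this size would recur with the amide portions of compound 2 and compound 3, which are shown only with a propyl chain.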